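Swapping Methoxy for Bromo in an Antiproliferative Compound

The compounds below may be only part of what the source reports. "The series", "measured", "known", "first", "only" and "open" are said of these compounds alone.

- compound 1 `COc1cc(O)c(C(=O)/C=C/c2ccc(OC)c(OC)c2)c(OC)c1`: 27600 nM
- compound 2 `COc1cc(O)c(C(=O)/C=C/c2cccc(OC)c2OC)c(OC)c1`: 3500 nM
- compound 3 `COc1ccc(/C=C/C(=O)c2c(OC)cc(OC)cc2OCC=C(C)C)cc1`: 7600 nM

In a functional assay on HCT-116 cells (Homo sapiens) for antiproliferative activity, read by sulforhodamine B assay, with a stated time of 48 h (on this read-out lower numbers stand for stronger inhibition and higher numbers for weaker inhibition), compound 3 gives 7600 nM, the middle of the three numbers, higher than the number for compound 2 and lower than the number for compound 1. Compound 4 `COc1cc(OC)c(C(=O)/C=C/c2ccc(Br)cc2)c(OCC=C(C)C)c1` has bromo in place of methoxy on an aromatic carbon, para to a large group (bromo in place of methoxy on an aromatic carbon). For the measured compounds named here, no measured pair of compounds isolates this change, so its direction cannot be read from the data. The expected change, a 1.3-fold lower number from compound 3 to compound 4 (0.10 log units; within the scatter), stays within the usual scatter. The range is kept wide, since compound 2 at 3500 nM and compound 1 at 27600 nM lie far apart. The estimated value for compound 4 is 6000 nM, with an expected range from 2000 nM to 18000 nM.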

Compound 4, half-maximal inhibitory concentration: 2100 nM
For compound 4 the middle estimate is 2.9-fold (0.46 log units) above the measured one, and the stated range covers the measured number.
By their numbers in this assay, from the lowest: compounds 4 and 2 (each within the scatter of the next); then compound 3; then compound 1.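

For the compounds shown here, compound 3 and compound 4 are the only pair here that differ in one place, and in this assay the change from 4-methoxyphenyl to 4-bromophenyl gives a 3.6-fold lower number from compound 3 to compound 4 (0.56 log units; beyond the scatter). This shows that the number responds to the group held on this aromatic carbon, para to a large group, at least in this one pair. Nothing available explains why the number moves in this direction.

From the compounds shown here alone, whether chloro, a nitrile or an amine in the same place would move the number in the same direction remains open. A single pair also leaves open whether bromo would have the same effect on the cores of compound 1 and compound 2.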